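From compound 3 to compound 4: one chloro added

The source may hold more compounds than are shown below. What is called first, only, known or untested is meant among the compounds shown, and "the series" means these compounds.

For the measured compounds named here, the series so far holds compound 1 (`O=C(CN1CCN(C(=O)c2ccccc2)CC1)N1CCN(CCCc2c[nH]c3ccccc23)CC1`), compound 2 (`O=C(CN1CCN(C(=O)c2ccc(Cl)cc2)CC1)N1CCN(CCCc2c[nH]c3ccccc23)CC1`) and compound 3 (`O=C(CN1CCN(C(=O)c2ccccc2)CC1)N1CCN(CCCc2c[nH]c3ccc(F)cc23)CC1`). In an ADME assay on SH-SY5Y cells (Homo sapiens) for cytotoxicity, read by MTT assay, with a stated time of 72 h (on this read-out lower numbers stand for stronger inhibition and higher numbers for weaker inhibition), compound 1 gives > 200000 nM, which is a limit of the assay and not a number. Compound 3 gives 146000 nM and compound 2 gives 139000 nM. Going by the values given here, these two numbers lie within the scatter of each other, so compound 3 is not separated from its only measured neighbour.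

Compound 4 (`O=C(CN1CCN(C(=O)c2ccc(Cl)cc2)CC1)N1CCN(CCCc2c[nH]c3ccc(F)cc23)CC1`) departs from compound 3 by chloro in place of hydrogen on an aromatic carbon, phenyl to 4-chlorophenyl.

The same change appears in one measured step, an at least 1.4-fold lower number from compound 1 to compound 2 (0.15 log units; that floor lies within the scatter). A fluoro change elsewhere gives an at least 1.3-fold lower number from compound 1 to compound 3 (0.13 log units; that floor lies within the scatter). Both steps start from compound 1, so each is only a floor set by the limit of > 200000 nM in this assay, at which 1 of the 3 values shown sits. Neither shows a true size, but both point towards lower numbers in this assay.

A modest shift in that direction is therefore expected, and it may stay within the scatter. The estimated step is a 1.5-fold lower number from compound 3 to compound 4 (0.16 log units; within the scatter). For compound 4 the expected value is 100000 nM, with an estimated range of 50000 nM to 180000 nM.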

Compound 4, half-maximal inhibitory concentration: 125000 nM
The estimate for compound 4 lay 1.3-fold (0.10 log units) below the measured number; measured number inside the range.
By their numbers in this assay, from the lowest: compounds 4, 2 and 3 (each within the scatter of the next). At a limit, above all of these: compound 1.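

In this assay, the change from phenyl to 4-chlorophenyl and the fluoro change now each have a step with a number at both ends, a 1.2-fold lower number from compound 3 to compound 4 (0.07 log units; within the scatter) and a 1.1-fold lower number from compound 2 to compound 4 (0.05 log units; within the scatter), and neither leaves the scatter. For chloro in place of hydrogen on an aromatic carbon, the size of the step on the core of compound 1 remains unsettled: the same change on two cores in this assay, an at least 1.4-fold lower number (0.15 log units; that floor lies within the scatter) from compound 1 to compound 2 and a 1.2-fold lower number (0.07 log units; within the scatter) from compound 3 to compound 4; the limit leaves it open whether they differ. The fluoro change stands the same way: the same change on two cores in this assay, an at least 1.3-fold lower number (0.13 log units; that floor lies within the scatter) from compound 1 to compound 3 and a 1.1-fold lower number (0.05 log units; within the scatter) from compound 2 to compound 4; the limit leaves it open whether they differ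

Going by these compounds, whether another group at this place on the six-membered aromatic ring, such as an amine or a carboxylic acid, would move the number beyond the scatter stays open. On these data alone, compound 1 gives > 200000 nM, which is a limit of the assay and not a number, so the true size of both steps that start from compound 1 also stays open.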